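The compounds below may be only part of what the source reports. "The series", "measured", "known", "first", "only" and "open" are said of these compounds alone.

- Compound 1 `COc1ccc2nccc(CC[C@H]3OC[C@H](NCc4ccc5c(n4)NC(=O)CS5)CO3)c2c1`: 31000 nM
- Compound 2 `COc1ccc2nccc(CC[C@H]3OC[C@H](NCc4ccc5c(c4)OCCO5)CO3)c2c1`: 7400 nM
- Compound 3 `COc1ccc2nccc(CC[C@H]3OC[C@H](NCc4ccc5c(n4)NC(=O)CO5)CO3)c2c1`: not yet measured

In an ADME assay on K562 cells (Homo sapiens) for antiproliferative activity (on this read-out lower numbers stand for stronger inhibition and higher numbers for weaker inhibition), compound 2 holds the lower of the two numbers at 7400 nM. The change to compound 3 is a group of 11 heavy atoms (7 carbon, 2 nitrogen, 2 oxygen; one six-membered non-aromatic ring with 2 hetero atoms, one six-membered aromatic ring with 1 hetero atom) in place of a group of 10 heavy atoms (8 carbon, 2 oxygen; one six-membered non-aromatic ring with 2 hetero atoms, one six-membered aromatic ring of carbon only), on a saturated chain carbon bound to an amine nitrogen. The 2,3-dihydro-1,4-benzodioxin-6-yl group leaves, and the entering group adds a hydrogen-bond donor and a double bond outside aromatic rings.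

Among the measured compounds shown here, the only measured step bearing on this is a 4.2-fold lower number from compound 1 to compound 2 (0.62 log units; beyond the scatter), a modest one. The group it removes has the same ring description as the group entering compound 3, but holds sulfur where that group holds oxygen. The new change therefore runs roughly backwards along that step, towards compound 1 at 31000 nM. No measurement shows what replacing that sulfur with oxygen does, so the size is uncertain. A rise of similar or slightly smaller size is expected, in the direction of weaker inhibition. The expected change is a 2.7-fold higher number from compound 2 to compound 3 (0.43 log units; beyond the scatter). For compound 3 the estimated value is 20000 nM, with an expected range of 8000 nM to 45000 nM.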

Compound 3, half-maximal inhibitory concentration: 24000 nM
Estimate against measurement, compound 3: 1.2-fold (0.08 log units) below; the range from low to high includes it.
By their numbers in this assay, from the lowest: compound 2; then compounds 3 and 1 (each within the scatter of the next).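

In this assay, a 3.2-fold higher number from compound 2 to compound 3 (0.51 log units; beyond the scatter) shows that the group entering compound 3, not only the sulfur-bearing group of compound 1, sits on the weaker side of the 2,3-dihydro-1,4-benzodioxin-6-yl group at this saturated chain carbon bound to an amine nitrogen. The exchange of sulfur for oxygen within the non-aromatic ring, seen as a 1.3-fold lower number from compound 1 to compound 3 (0.11 log units; within the scatter), stays within the scatter, so compound 1 and compound 3 cannot be separated in this assay and the sulfur atom alone does not decide the result at this place. No data available here explain the difference between these groups.

The compounds shown leave open whether the gap to compound 2 follows the aromatic ring with its hetero atom or the entering group's added double bond and hydrogen-bond donor, as no compound changes these features separately. A plain phenyl group, or a pyridinyl group carrying the same 1,4-dioxane ring as compound 2, at the same place would help separate these features.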